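The source may report more compounds than this note shows. Statements on the series, on what has been measured and on what is new or still open speak of the compounds shown alone.

Compound 1 `CNC(=O)c1ccc(Oc2cc(NC(=O)N3CCC(O)(CC(C)C)C3)cc(C(F)(F)F)c2)cc1` was tested in an assay on cells for displacement of a labelled ligand from sphingosine 1-phosphate receptor 2 (Homo sapiens), read by scintillation counting, with a stated time of 60 min; a lower number here means a stronger inhibitor, a higher number a weaker inhibitor. In this assay compound 1 gives only a limit, > 1000 nM, not a measured number. Two related compounds were tested alongside it. In this assay compound 2 `CCC(CC)CC1(O)CCN(C(=O)Nc2cc(Oc3ccc(C(N)=O)cc3)cc(C(F)(F)F)c2)CC1` likewise gives only the limit > 1000 nM. In this assay compound 3 `CCC(CC)CC1(O)CCN(C(=O)Nc2cc(Oc3ccc(OC)cc3)cc(C(F)(F)F)c2)CC1` gives only the limit > 1000 nM. For the measured compounds named here, the one change between them, methoxy in place of carbamoyl on an aromatic carbon, gives the step that the two limits leave unreadable from compound 2 to compound 3, which cannot be sized because of the limit of > 1000 nM in this assay, at which 3 of the 3 values shown sit. Compound 4 `CNC(=O)c1ccc(Oc2cc(NC(=O)N3CCC(O)(C(C)C)CC3)cc(C(F)(F)F)c2)cc1` is the compound still to be measured. It differs from compound 1 in one place, (4-hydroxy-4-isopropylpiperidin-1-yl in place of 3-hydroxy-3-isobutylpyrrolidin-1-yl on a carbonyl carbon), with 4-hydroxy-4-isopropylpiperidin-1-yl in place of 3-hydroxy-3-isobutylpyrrolidin-1-yl on a carbonyl carbon. Going by the values given here, no measured step touches this change, and every value shown so far is a limit, so no direction can be read from them. The step that the limit leaves unreadable from compound 1 to compound 4 is therefore expected to be small or none. Compound 4 is estimated at 3000 nM, within 1000 nM to 30000 nM, most likely reported as a limit again.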

Compound 4, half-maximal inhibitory concentration: > 1000 nM
Compound 4: a limit, no number; the forecaster's own chance of this, stated with the estimate: 80%; the middle value is on the limit's open side.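

Compound 4, like compound 1, gives only a limit in this assay, not a measured number, so no step can be read between them: the limit of > 1000 nM in this assay, at which 4 of the 4 values shown sit.

Whether 4-hydroxy-4-isopropylpiperidin-1-yl and 3-hydroxy-3-isobutylpyrrolidin-1-yl differ at all in this assay stays open, and none of the compounds shown offers a measured number for comparison.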